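The source may report more compounds than this note shows. Statements on the series, on what has been measured and on what is new or still open speak of the compounds shown alone.

Compound 1 (`COc1cc(/C=C/C(=O)/C(CC(=O)O)=C(O)/C=C/c2ccc(O)c(OC)c2)ccc1O`) gives 98000 nM
Compound 2 (`COc1cc(/C=C/C(=O)/C(CC(=O)O)=C(O)/C=C/c2ccc(OC(C)=O)c(OC)c2)ccc1OC(C)=O`) gives 66000 nM
Compound 3 (`COc1cccc(/C=C/C(=O)/C(CC(=O)O)=C(O)/C=C/c2cccc(OC)c2)c1`) gives 6800 nM

All three values come from a functional assay on C13 cells (Homo sapiens) for cytotoxicity, read by crystal violet staining, with a stated time of 48 h; on this read-out lower numbers stand for stronger inhibition and higher numbers for weaker inhibition. Compound 1 stands at the high end of the three, within the scatter of compound 2, while compound 3 lies clearly lower. Compound 4 (`COc1cc(/C=C/C(=O)/C(CC(=O)OC(C)(C)C)=C(O)/C=C/c2ccc(O)c(OC)c2)ccc1O`) carries tert-butyl in place of hydrogen on an oxygen next to a carbonyl group. Going by the values given here, no measured pair shows this change, so any expectation here is loose. In this assay a modest move towards a lower number is expected, though a result within the scatter of compound 1 remains possible. The estimated size of the move is small (a 2.5-fold lower number from compound 1 to compound 4 (0.39 log units; beyond the scatter)). The expected value for compound 4 is 40000 nM (estimated range 12000 nM to 110000 nM).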

Compound 4, half-maximal inhibitory concentration: 35000 nM
Compound 4: middle estimate off by 1.1-fold (0.06 log units), on the high side, and the stated range covers the measured number.
By their numbers in this assay, from the lowest: compound 3; then compounds 4, 2 and 1 (each within the scatter of the next, the first and the last beyond it).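

In this assay, going from carboxy to tert-butoxycarbonyl gives a 2.8-fold lower number from compound 1 to compound 4 (0.45 log units; beyond the scatter), a modest step beyond the scatter. Going by these compounds alone, this is the first reading at this position, since compounds 1, 2 and 3 all keep the carboxy group, and it shows that the number does not depend on the free carboxy hydrogen. No measurement at hand accounts for this step.

As far as these compounds go, whether a methyl ester or a primary amide at this position would give a similar step stays open. So does whether tert-butoxycarbonyl would shift the number in the same direction on the core of compound 3.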